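Replacing methyl with nitro in compound 3

A few compounds are considered here, and "the series" means these few. Any claim that something is new, unique, unknown or untested is made for them only; others in the source may bear on it.

Measured in a functional assay on A549 cells (Homo sapiens) for antiproliferative activity, read by MTT assay, with a stated time of 48 h; a lower number here means a stronger inhibitor, a higher number a weaker inhibitor:
compound 1 `O=[N+]([O-])c1cccc(-c2nn(-c3ccccc3)cc2C(Nc2nc3ccccc3s2)c2c(O)ccc3ccccc23)c1`: 32000 nM
compound 2 `Cc1ccc2nc(NC(c3cn(-c4ccccc4)nc3-c3cccc([N+](=O)[O-])c3)c3c(O)ccc4ccccc34)sc2c1`: 57400 nM
compound 3 `Cc1ccc(-c2nn(-c3ccccc3)cc2C(Nc2nc3cc(C)c(C)cc3s2)c2c(O)ccc3ccccc23)cc1`: 31200 nM

The values of compound 1 and compound 2 both lie within the scatter of compound 3, so the three numbers set no order. Compound 4 `Cc1cc2nc(NC(c3cn(-c4ccccc4)nc3-c3ccc([N+](=O)[O-])cc3)c3c(O)ccc4ccccc34)sc2cc1C` differs from compound 3 in one place: nitro in place of methyl on an aromatic carbon. This is nitro in place of methyl on an aromatic carbon, para to a large group. Going by the values given here, no measured step tests this change. Among the compounds with values here, the only step, a 1.8-fold higher number from compound 1 to compound 2 (0.25 log units; within the scatter), is methyl in place of hydrogen on an aromatic carbon, a different change. Compound 1, which also carries a nitro group, gives 32000 nM. No shift beyond the scatter is therefore expected in this assay. The expected step is a 1.2-fold higher number from compound 3 to compound 4 (0.09 log units; within the scatter). Compound 4 is expected at 38000 nM, with an estimated range of 17000 nM to 85000 nM.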

Compound 4, half-maximal inhibitory concentration: 41900 nM
The estimate for compound 4 lay 1.1-fold (0.04 log units) below the measured number; low and high end bracket the measured number.
By their numbers in this assay, from the lowest: compounds 3, 1, 4 and 2 (each within the scatter of the next).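

In this assay, going by these compounds alone, the change from 4-methylphenyl to 4-nitrophenyl gives a 1.3-fold higher number from compound 3 to compound 4 (0.13 log units; within the scatter), the first direct reading of this change at this position. Nitro in place of methyl, para to a large group, therefore does not move the number beyond the scatter, and the two groups cannot be told apart here. The compounds shown leave open whether an amine or a carboxylic acid at this position would give a number beyond the scatter of compound 3. No evidence bears on why the two groups read alike.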